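One Added Methyl on Compound 2

A few compounds are considered here, and "the series" means these few. Any claim that something is new, unique, unknown or untested is made for them only; others in the source may bear on it.

Two small molecules have so far been tested in an ADME assay on Huh-7 cells (Homo sapiens) for cytotoxicity; on this read-out lower numbers stand for higher toxicity in this test and higher numbers for lower toxicity in this test. Compound 1 `O=c1[nH]c(=O)n([C@H]2C[C@@H](O)[C@@H](CO)O2)cc1Cl` gives > 763000 nM, which is a limit of the assay and not a number. Compound 2 `O=c1ccn([C@@H]2O[C@H](CO)[C@@H](F)[C@@H]2O)c(=O)[nH]1` gives > 813000 nM, which is likewise a limit. Neither result is an exact figure, so the two compounds cannot be put in order, and compound 2 stands only at its limit.

Compound 3 `Cc1cn([C@@H]2O[C@H](CO)[C@@H](F)[C@@H]2O)c(=O)[nH]c1=O` is compound 2 with one change: methyl in place of hydrogen on an aromatic carbon. For the measured compounds named here, no pair of measured compounds here shows what such a change does. The forecast therefore rests on the small size of this change and on compound 2, with its > 813000 nM. In this assay, no shift beyond the usual scatter is expected in either direction, and the expected step is an at least 1.0-fold lower number from compound 2 to compound 3 (0.02 log units; that floor lies within the scatter). The estimate for compound 3 is 770000 nM, with an expected range of 350000 nM to 1000000 nM, and the result may well be reported only as a limit again.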

Compound 3, half-maximal cytotoxic concentration: > 769000 nM
Compound 3 ended at the assay's limit; the forecaster's own chance of this, stated with the estimate: 85%; the middle value does not contradict the limit.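

In this assay compound 3 gives > 769000 nM, which is a limit and not a number. Compound 2 also stands only at a limit, and the step from compound 2 to compound 3 cannot be read. The compounds shown leave open what the added methyl does to this read-out, and where any exact value would lie.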